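Swapping a Hydroxymethyl Group for Fluorine

The source may report more compounds than this note shows. Statements on the series, on what has been measured and on what is new or still open speak of the compounds shown alone.

Of the compounds shown here, two have been measured in an assay for binding affinity to 17-beta-hydroxysteroid dehydrogenase type 1 (Homo sapiens), with a stated time of 20 min, tested at 1 uM; on this read-out lower numbers stand for less inhibition and higher numbers for more inhibition at the one concentration tested (going by the name of the read-out). Compound 1 `COc1ccc(-c2ccc3c(O)cccc3c2)cc1` gives 28%, and compound 2 `OCc1ccc(-c2ccc3c(O)cccc3c2)cc1` gives 14%. Among the compounds with values here, compound 2 therefore stands lower of the two, because the only step known so far, a number 14 percentage points lower from compound 1 to compound 2 (beyond the scatter), moves the number down by a modest amount. Compound 3 `Oc1cccc2cc(-c3ccc(F)cc3)ccc12` has not yet been measured. It differs from compound 2 in one place: fluoro in place of hydroxymethyl on an aromatic carbon. Within the data shown here, the single measured step also exchanges a group on an aromatic carbon, so it bears on this change only loosely; it shows that such an exchange can move the number by a modest amount in either direction. For compound 3 the step of a number 8 percentage points higher from compound 2 to compound 3 (within the scatter) is expected to be small, either within the scatter or a modest rise. Compound 3 is estimated at 22%, with a range from 5% to 40%.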

Compound 3, a percentage reported as inhibition, at one concentration (the size of the read-out at that concentration, not a potency): < 10%
Compound 3: no number, only a limit; the forecaster's own chance of this, stated with the estimate: 0%; middle value at least 12 percentage points away from the limit.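

At this place, para to a large group, compound 3 gives < 10% in this assay, and that value is a limit of the assay, not a number. Fluoro in place of hydroxymethyl gives a number at least 4 percentage points lower from compound 2 to compound 3 (that floor lies within the scatter), so no real difference between these two groups can be claimed, while fluoro in place of methoxy gives a number at least 18 percentage points lower from compound 1 to compound 3 (beyond the scatter). Compound 1 therefore stands highest of the three, and the number falls beyond the scatter whether hydroxymethyl or fluoro takes the place of its methoxy.

How far compound 3 truly lies under compound 2 stays open: the limit of < 10% in this assay, at which 1 of the 3 values shown sits.

Also open, on these data alone, is whether an ethoxy group, an amine or a carboxylic acid at this place would match methoxy or go beyond it.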